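Benzyl in Place of Ethyl on the Amide of Compound 1

A few compounds are considered here, and "the series" means these few. Any claim that something is new, unique, unknown or untested is made for them only; others in the source may bear on it.

Compound 1 `CCNC(=O)CC[C@H](NS(=O)(=O)c1ccc([N+](=O)[O-])cc1)C(=O)O`: 4800 nM
Compound 2 `CC(C)CNC(=O)CC[C@H](NS(=O)(=O)c1ccc([N+](=O)[O-])cc1)C(=O)O`: 5140 nM

Compound 1 stands at the lowest of the two numbers in an assay for inhibition of matrix metalloproteinase-9 (Homo sapiens), with stated times of 1 h, 1 min and 30 min (on this read-out higher numbers stand for weaker inhibition and lower numbers for stronger inhibition), with compound 2 as its nearest neighbour, and the step of a 1.1-fold higher number from compound 1 to compound 2 (0.03 log units; within the scatter) lies within the scatter. Compound 3 `O=C(CC[C@H](NS(=O)(=O)c1ccc([N+](=O)[O-])cc1)C(=O)O)NCc1ccccc1` is not yet measured. Among the compounds with values here, it differs from compound 1 by phenyl in place of methyl on a saturated chain carbon bound to an amide-type nitrogen, so the change sits at the same place as the one measured step. That step, a 1.1-fold higher number from compound 1 to compound 2 (0.03 log units; within the scatter), shows that enlarging the group on this carbon left this assay essentially unchanged. Within the data shown here, a phenyl is a larger entry than an isopropyl, but no measured compound bears a ring at this place, so nothing here points to a direction. Compound 3 is therefore expected to show a 1.1-fold lower number from compound 1 to compound 3 (0.03 log units; within the scatter), a step not beyond the scatter. The estimate for compound 3 is 4500 nM, with a range from 2000 nM to 10000 nM.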

Compound 3, half-maximal inhibitory concentration: 6370 nM
Compound 3: middle estimate off by 1.4-fold (0.15 log units), on the low side; the measured number falls inside the stated range.
By their numbers in this assay, from the lowest: compounds 1, 2 and 3 (each within the scatter of the next).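

In this assay the phenyl brings the first ring to this place, on a saturated chain carbon bound to an amide-type nitrogen, and the step it gives (a 1.3-fold higher number from compound 1 to compound 3 (0.12 log units; within the scatter)) stays within the scatter. Set against the isopropyl, the phenyl also gives a step within the scatter (a 1.2-fold higher number from compound 2 to compound 3 (0.09 log units; within the scatter)), so the methyl, isopropyl and phenyl entries read alike across these three compounds, and a six-membered aromatic ring of carbon only is accommodated here as well as the open-chain groups. No accompanying evidence bears on this result.

The compounds shown leave open whether an amine, a carboxylic acid or a longer chain at this place would read the same way. As far as these compounds go, whether changes elsewhere on the shared core would also stay within the scatter remains open too.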